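A few compounds are considered here, and "the series" means these few. Any claim that something is new, unique, unknown or untested is made for them only; others in the source may bear on it.

Compound 1 `CCC1(Cc2ccccc2)OS(=O)(=O)C=C1OCCCCc1ccccc1` gives 99000 nM in an ADME assay on HEL cells (Homo sapiens) for cytotoxicity, with a stated time of 3 days; on this read-out lower numbers stand for higher toxicity in this test and higher numbers for lower toxicity in this test. Compound 2 `CCC1(Cc2ccccc2)OS(=O)(=O)C=C1OC` sits at the limit of this assay, > 200000 nM. Compound 3 `CCC1(Cc2ccccc2)OS(=O)(=O)C=C1OCC1CCCCC1` likewise sits at the limit of this assay, > 200000 nM.

Compound 3 therefore stands not on a number but on a limit; it shares that limit with one other member of the series (the limit of > 200000 nM in this assay, at which 2 of the 3 values shown sit). The step to compound 4 `CCC1(Cc2ccccc2)OS(=O)(=O)C=C1OCc1ccc([N+](=O)[O-])cc1` is 4-nitrophenyl in place of cyclohexyl on a saturated chain carbon bound to an oxygen on an unsaturated carbon.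

For the measured compounds named here, three measured steps touch the same place on the core. Going by the values given here, from the one numbered value the two replacements each reach a limit: an at least 2.0-fold higher number from compound 1 to compound 2 (0.30 log units; that floor lies within the scatter) and an at least 2.0-fold higher number from compound 1 to compound 3 (0.30 log units; that floor lies within the scatter). The step between the two limits cannot be read: a step that the two limits leave unreadable from compound 2 to compound 3. Among the compounds with values here, every change seen at this position so far has moved the read-out upward to the limit or left it unreadable; no change has lowered it. For the exchange of cyclohexyl for 4-nitrophenyl there is no measured comparison, so no step beyond the scatter is expected in this assay, and a value again at or close to the limit is the likeliest outcome, with the numbered value of compound 1 marking how far down a number might still fall.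

Compound 4 is expected at 160000 nM, within 70000 nM to 250000 nM, which corresponds to an estimated step of an at least 1.2-fold lower number from compound 3 to compound 4 (0.09 log units; that floor lies within the scatter).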

Compound 4, half-maximal cytotoxic concentration: < 200000 nM
Compound 4: no number, only a limit; the forecaster's own chance of this, stated with the estimate: 55%; the middle value is on the limit's open side.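

In this assay compound 4 carries a limit, < 200000 nM, and not a number. With 4-nitrophenyl on a saturated chain carbon bound to an oxygen on an unsaturated carbon, this position gives its first change that cannot have raised the read-out from the upper limit: a number no higher from compound 3 to compound 4 (the limit leaves the size open), and a number no higher from compound 2 to compound 4 (the limit leaves the size open), though the size of both steps, like the step involving compound 1, cannot be read. Limits now stand on both sides of the same concentration at this position, and the lower one is new: the limit of < 200000 nM in this assay, at which 1 of the 4 values shown sits.

As far as these compounds go, how far down compound 4 lies stays open, and with it whether it comes anywhere near compound 1 at 99000 nM. Also open, from the compounds shown here alone, is whether a longer chain ending in 4-nitrophenyl, or an amine or a carboxylic acid at this place, would give a number in this assay instead of another limit.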